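The source may report more compounds than this note shows. Statements on the series, on what has been measured and on what is new or still open speak of the compounds shown alone.

Measured compounds in a functional assay on NCI-H522 cells (Homo sapiens) for inhibition, read by sulforhodamine B assay, with a stated time of 48 h; a lower number here means a stronger inhibitor of growth, a higher number a weaker inhibitor of growth:
compound 1 `Nc1cc(N)c2nc(-c3ccccc3)c(Oc3ccc(Cl)c(Cl)c3)nc2c1`: 8320 nM
compound 2 `CCOC(=O)[C@H](CCC(=O)O)NC(=O)c1ccc(Sc2nc3cc(N)cc(N)c3nc2-c2ccccc2)cc1`: 21400 nM
compound 3 `CCOC(=O)[C@H](CCC(=O)O)NC(=O)c1ccc(Oc2nc3cc(N)cc(N)c3nc2-c2ccccc2)cc1`: 27500 nM

Compound 1 gives the lowest of the three numbers in this assay; its gaps to compound 2 and to compound 3 both lie beyond the usual scatter, so it is the strongest growth inhibitor of the three measured here.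

Compound 4 `Nc1cc(N)c2nc(-c3ccccc3)c(Oc3ccc(F)cc3)nc2c1` has not yet been measured. It differs from compound 1 in one place: 4-fluorophenyl in place of 3,4-dichlorophenyl on an oxygen on an aromatic ring.

Among the compounds with values here, no step between measured compounds isolates this kind of exchange, so the expected size of the step from compound 1 to compound 4 rests on compound 1 alone and on its value 8320 nM. A small step toward a weaker inhibitor is expected, a 1.4-fold higher number from compound 1 to compound 4 (0.16 log units; within the scatter), not clearly beyond the scatter. The estimate for compound 4 is 12000 nM, with a range from 4000 nM to 40000 nM.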

Compound 4, concentration for 50% growth inhibition: 64600 nM
Compound 4: the middle estimate sits 5.4-fold (0.73 log units) below what was measured, outside the stated range (above it).
By their numbers in this assay, from the lowest: compound 1; then compounds 2 and 3 (each within the scatter of the next); then compound 4.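

In this assay, the group on this oxygen clearly matters: 4-fluorophenyl in place of 3,4-dichlorophenyl gives a 7.8-fold higher number from compound 1 to compound 4 (0.89 log units; beyond the scatter). Within the data shown here, this is the first reading of this position alone, since compounds 2 and 3 differ from compound 1 in more than one place. No measured evidence bears on the size of this step.

The exchange alters both the halogen and the number of halogen atoms, so the compounds shown do not separate these two changes. As far as these compounds go, an unsubstituted phenyl, or a phenyl carrying a single chlorine, on the same oxygen remains open.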